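The source may report more compounds than this note shows. Statements on the series, on what has been measured and on what is new or still open speak of the compounds shown alone.

Working notes on the aryl series.

Three compounds on the shared core have numbers in a functional assay on KBVIN cells (Homo sapiens) for antiproliferative activity, read by sulforhodamine B assay, with a stated time of 3 days; on this read-out higher numbers stand for an effect only at larger amounts of compound and lower numbers for an effect already at smaller amounts. Compound 1 `CCCc1ccc(-c2cc(=O)c3c(o2)C(CC)(CC)C(=O)C(CC)=C3O)cc1` gives 12.2 uM. Compound 2 `CCC1=C(O)c2c(oc(-c3cccc(OC)c3)cc2=O)C(CC)(CC)C1=O` gives 1.22 uM, and compound 3 `CCC1=C(O)c2c(oc(-c3ccccc3OC)cc2=O)C(CC)(CC)C1=O` gives 3.26 uM. The steps are all modest: a 10-fold lower number from compound 1 to compound 2 (1.00 log units; beyond the scatter), a 3.7-fold lower number from compound 1 to compound 3 (0.57 log units; beyond the scatter) and a 2.7-fold higher number from compound 2 to compound 3 (0.43 log units; beyond the scatter). Compound 3 therefore stands second highest of the three, with compound 2 nearest and compound 1 furthest.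

Compound 4 `CCC1=C(O)c2c(oc(-c3cc(C)cc(C)c3)cc2=O)C(CC)(CC)C1=O` is not yet measured. It differs from compound 3 in one place: 3,5-dimethylphenyl in place of 2-methoxyphenyl on an aromatic carbon. Every measured step bears on this change, since each swaps one group on the same aromatic carbon; none of them carries a 3,5-dimethylphenyl, and the two methoxy-bearing compounds 2 and 3 gave the lowest numbers, while compound 1, which like compound 4 carries a group with no hydrogen-bond acceptor, gave the highest. The expectation for compound 4 is a number somewhat above that of compound 3, by about a 1.7-fold higher number from compound 3 to compound 4 (0.23 log units; within the scatter), though a step within the scatter cannot be excluded. Compound 4 is thus estimated at 5.5 uM, with a range from 1.8 uM to 16 uM in this assay.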

Compound 4, concentration for half-maximal effect: 0.45 uM
Estimate against measurement, compound 4: 12-fold (1.09 log units) above; the whole stated range lies above it.
By their numbers in this assay, from the lowest: compound 4; then compound 2; then compound 3; then compound 1.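

At this aromatic carbon, next to the ring oxygen, a methoxy group is not required for the lowest number in the series: in this assay, 3,5-dimethylphenyl gives a 7.2-fold lower number from compound 3 to compound 4 (0.86 log units; beyond the scatter) and also a 2.7-fold lower number from compound 2 to compound 4 (0.43 log units; beyond the scatter), so it outdoes both methoxyphenyl groups while counting no hydrogen-bond acceptor. Going by these compounds alone, the aryl groups without an acceptor now stand at the two ends of the order, with a 27-fold lower number from compound 1 to compound 4 (1.43 log units; beyond the scatter) as the only large step so far, so the presence or absence of an acceptor does not sort these four compounds, and compound 1 and compound 4 go against any reading built on it. Nothing measured on these compounds bears on why 3,5-dimethylphenyl gives the lowest number.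

The compounds shown cannot separate the contribution of the methyl groups from that of their placement, since plain phenyl, a methylphenyl and 3,5-dimethoxyphenyl do not appear among them. They also leave open how this aromatic carbon responds to a ring carrying an amine or a carboxylic acid, and whether the order holds outside this assay.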